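The source may report more compounds than this note shows. Statements on the series, on what has been measured and on what is new or still open speak of the compounds shown alone.

Measured so far in a functional assay on HL-60 cells (Homo sapiens) for antiproliferative activity; a higher number here means a weaker inhibitor, a lower number a stronger inhibitor:
compound 1, `Cn1cc(NC(=O)c2ccc(CN)cc2)cc1C(=O)Nc1ccc(CN)cc1`: 5400 nM
compound 2, `NCc1ccc(NC(=O)c2cc(NC(=O)c3ccc(CN)cc3)c[nH]2)cc1`: 1700 nM

In this assay compound 1 gives 5400 nM and compound 2 gives 1700 nM. Going by the values given here, compound 2 thus holds the lower of the two numbers in hand; the single measured step, a 3.2-fold lower number from compound 1 to compound 2 (0.50 log units; beyond the scatter), separates it from compound 1 and lies beyond the scatter.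

Compound 3, `NCc1ccc(NC(=O)c2cc(NC(=O)c3ccc(CN)cc3)cn2Cc2ccccc2)cc1`, is not yet measured. It differs from compound 2 in one place: benzyl in place of hydrogen on an aromatic nitrogen. Among the compounds with values here, the only measured step that touches this position is a 3.2-fold lower number from compound 1 to compound 2 (0.50 log units; beyond the scatter), in which a methyl on the same aromatic nitrogen gave way to hydrogen and the number fell. The step to compound 3 runs the other way and puts a much larger group on that nitrogen, so the number is expected to rise rather than fall, by at least as much as the measured step, with room for a larger loss. For compound 3 in this assay the estimated value is 7000 nM, expected to lie between 2500 nM and 20000 nM, an expected step of a 4.1-fold higher number from compound 2 to compound 3 (0.61 log units; beyond the scatter).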

Compound 3, half-maximal inhibitory concentration: 8200 nM
The estimate for compound 3 lay 1.2-fold (0.07 log units) below the measured number, and the stated range covers the measured number.
By their numbers in this assay, from the lowest: compound 2; then compounds 1 and 3 (each within the scatter of the next).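

Hydrogen on the aromatic nitrogen now stands against two substituents, methyl and benzyl, and compound 2 keeps the lowest number against both in this assay, with a 4.8-fold higher number from compound 2 to compound 3 (0.68 log units; beyond the scatter) as the new step. Going from methyl to benzyl places phenyl on the saturated chain carbon bound to the aromatic nitrogen, and a 1.5-fold higher number from compound 1 to compound 3 (0.18 log units; within the scatter) leaves compound 1 and compound 3 unseparated, so across these two substituents the added phenyl makes no difference that can be read, while the step away from hydrogen does. No measurement is available here that bears on the reason for these steps.

Whether any group on this nitrogen can match or improve on hydrogen stays open, since the only substituents shown are methyl and benzyl, both carbon-only, and a 2-aminoethyl chain or a carboxymethyl group could read differently. Both aminomethyl groups are also the same in all the compounds shown, so it remains open whether the step from hydrogen to benzyl keeps its size when either of them is replaced, for instance by a longer aminoethyl chain.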